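The compounds below may be only part of what the source reports. "The series", "measured", "known", "first", "only" and "open" are said of these compounds alone.

Measured in a functional assay on A549 cells (Homo sapiens) for antiproliferative activity, read by MTT assay, with a stated time of 72 h; a lower number here means a stronger inhibitor, a higher number a weaker inhibitor:
Compound 1 `COc1ncc(-c2ccc3c(c2)N(c2ccc(C)cc2)C(=O)CO3)cc1NS(=O)(=O)c1ccc(F)cc1` gives 5870 nM.
Compound 2 `COc1ncc(-c2ccc3c(c2)N(C2CCCCC2)C(=O)CO3)cc1NS(=O)(=O)c1ccc(F)cc1` gives 24600 nM.
Compound 3 `O=C1COc2ccc(-c3cnc4ccccc4c3)cc2N1C1CCCCC1` reaches only a limit of this assay, > 40000 nM.

Compound 2 and compound 1 differ in one place, (4-methylphenyl in place of cyclohexyl on an amide-type nitrogen in a ring), and that change gave a 4.2-fold lower number from compound 2 to compound 1 (0.62 log units; beyond the scatter). Compound 4 `Cc1ccc(N2C(=O)COc3ccc(-c4cnc5ccccc5c4)cc32)cc1`, not yet measured, stands to compound 3 by the same change, (4-methylphenyl in place of cyclohexyl on an amide-type nitrogen in a ring), at the same place. How the core of compound 3 differs from the core of compound 2 is not broken down here. Compound 3 sits at the limit (the limit of > 40000 nM in this assay, at which 1 of the 3 values shown sits), so there is no number to carry the earlier step onto. The step expected in this assay is an at least 2.0-fold lower number from compound 3 to compound 4 (0.30 log units; that floor lies within the scatter), resting on a 4.2-fold lower number from compound 2 to compound 1 (0.62 log units; beyond the scatter) applied to a starting point that is itself only a limit. Compound 4 is expected near 20000 nM, between 7000 nM and 45000 nM.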

Compound 4, half-maximal inhibitory concentration: > 40000 nM
Compound 4: a limit, no number; the forecaster's own chance of this, stated with the estimate: 40%; middle value at least 2.0-fold (0.30 log units) away from the limit.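

Compound 3 and compound 4 both stand at a limit of this assay, not at a number, so no step can be read between them: the limit of > 40000 nM in this assay, at which 2 of the 4 values shown sit.

As far as these compounds go, whether 4-methylphenyl in place of cyclohexyl lowers the number on the core of compound 3, as it does on the core of compound 2, stays open.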